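The source may hold more compounds than are shown below. What is called first, only, known or untested is meant among the compounds shown, and "the series" means these compounds.

Series notes. Compound 1 `COC(=O)c1cc(C2=C(c3cc(OC)c(OC)c(OC)c3)C(=O)CC2O[SiH2]C(C)(C)C)ccc1OC` carries a tert-butyl silyl ether on the shared core and a methoxycarbonyl on one aryl ring. In an ADME assay on HT-29 cells (Homo sapiens) for cytotoxicity, read by MTT assay, with a stated time of 72 h (a higher number here means a weaker inhibitor, a lower number a stronger inhibitor), compound 1 gives only a limit, > 100 ug/mL. Compound 2 `COc1ccc(C2=C(c3cc(OC)c(OC)c(OC)c3)C(=O)CC2OC(C)=O)cc1NC=O` likewise gives only a limit in this assay, < 1 ug/mL. Compound 3 `CCOC(=O)COc1ccc(C2=C(c3cc(OC)c(OC)c(OC)c3)C(=O)CC2O)cc1` also returns a limit in this assay, > 100 ug/mL. Among the measured compounds shown here, compound 1 therefore stands at the weak end of what has been seen so far, as the limit of > 100 ug/mL in this assay, at which 2 of the 3 values shown sit, shows, whereas the limit of < 1 ug/mL in this assay, at which 1 of the 3 values shown sits, marks the one strong value. From the compounds shown here alone, compound 4 `COc1ccc(C2=C(c3cc(OC)c(OC)c(OC)c3)C(=O)CC2O[SiH2]C(C)(C)C)cc1` is untested; it differs from compound 1 by hydrogen in place of methoxycarbonyl on an aromatic carbon. For the measured compounds named here, no step between measured compounds is available to size this change. Compound 4 is expected to remain weak, with an estimated 70 ug/mL (range 20 ug/mL to 200 ug/mL). The expected step of an at least 1.4-fold lower number from compound 1 to compound 4 (0.15 log units; that floor lies within the scatter) is within scatter.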

Compound 4, half-maximal inhibitory concentration: > 100 ug/mL
Compound 4 was reported as a limit; the forecaster's own chance of this, stated with the estimate: 55%; middle value at least 1.4-fold (0.15 log units) away from the limit.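

Compound 1 and compound 4 are both reported only as limits in this assay, so no step can be read between them. The compounds shown leave open what size, if any, the exchange of methoxycarbonyl for hydrogen has.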